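Swapping the Thiophene Arm for an Imidazole

The compounds below may be only part of what the source reports. "The series", "measured", "known", "first", "only" and "open" are said of these compounds alone.

The three measured compounds share one core and differ only in the aromatic ring that sits on the saturated chain carbon bound to the carbonyl carbon. Compound 1 `Cc1ccccc1N/C(=N\C#N)N1CCN(C(=O)Cc2ccsc2)C(c2ccccc2)C1` carries a thiophen-3-yl there and gives 71 nM in a functional assay for antagonist activity at P2X purinoceptor 7 (Homo sapiens), read by FLIPR and calcium flux (a lower number here means a stronger inhibitor, a higher number a weaker inhibitor), the highest of the three numbers, though every gap to the others lies within the scatter. Compound 2 `Cc1ccccc1N/C(=N\C#N)N1CCN(C(=O)Cc2cccnc2)C(c2ccccc2)C1` carries a pyridin-3-yl and gives 40 nM; compound 3 `Cc1ccccc1N/C(=N\C#N)N1CCN(C(=O)Cn2nccc2C)C(c2ccccc2)C1` carries a 5-methyl-1H-pyrazol-1-yl and gives 60 nM. The steps of a 1.8-fold lower number from compound 1 to compound 2 (0.25 log units; within the scatter) and a 1.2-fold lower number from compound 1 to compound 3 (0.07 log units; within the scatter) are both small, and so is a 1.5-fold higher number from compound 2 to compound 3 (0.18 log units; within the scatter).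

Compound 4 `Cc1ccccc1N/C(=N\C#N)N1CCN(C(=O)Cc2c[nH]cn2)C(c2ccccc2)C1` continues this series at the same place: 1H-imidazol-4-yl in place of thiophen-3-yl on a saturated chain carbon bound to a carbonyl carbon. The two steps that bear on it, from compound 1 to compound 2 and from compound 1 to compound 3, both replaced the thiophen-3-yl with a nitrogen-containing aromatic ring and neither moved the number beyond the scatter. The account therefore expects no step beyond the scatter here either, at most a slight drift toward a lower number, a 1.3-fold lower number from compound 1 to compound 4 (0.11 log units; within the scatter). Compound 4 is estimated at 55 nM, with a range from 20 nM to 160 nM.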

Compound 4, half-maximal inhibitory concentration: 1000 nM
Compound 4: middle estimate off by 18-fold (1.26 log units), on the low side; measured number above the stated range.
By their numbers in this assay, from the lowest: compounds 2, 3 and 1 (each within the scatter of the next); then compound 4.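

The position is not indifferent to the ring it carries. Where the thiophen-3-yl, pyridin-3-yl and 5-methyl-1H-pyrazol-1-yl arms all lie within the scatter of one another in this assay, the 1H-imidazol-4-yl brings a 14-fold higher number from compound 1 to compound 4 (1.15 log units; beyond the scatter) and a 17-fold higher number from compound 3 to compound 4 (1.22 log units; beyond the scatter) and also a 25-fold higher number from compound 2 to compound 4 (1.40 log units; beyond the scatter), so a nitrogen-containing aromatic ring on this saturated chain carbon does not by itself keep the number low. The counts show that the 1H-imidazol-4-yl enters with 1 hydrogen-bond donor and 2 hetero atoms where the thiophen-3-yl had 0 donors and 1 hetero atom, but nothing measured here explains the rise, and those counts remain a description of the change.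

The compounds shown leave open whether the rise goes with the hydrogen on the ring nitrogen or with the imidazole ring as a whole, a question that a 1-methyl-1H-imidazol-4-yl or a 1H-pyrazol-4-yl at the same place would bear on. Also open, from the compounds shown here alone, is how the series responds to a longer chain leading to the imidazole, or to an amine or a carboxylic acid in place of the ring.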